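Fluoro for chloro on a sulfonyl ring, second core

The source may report more compounds than this note shows. Statements on the series, on what has been measured and on what is new or still open speak of the compounds shown alone.

Compound 1 `N#C/C(=C\c1ccccc1OS(=O)(=O)c1ccc(Cl)cc1)C(=O)Nc1nnc(Cc2cccc3ccccc23)s1` and compound 2 `N#C/C(=C\c1ccccc1OS(=O)(=O)c1ccc(F)cc1)C(=O)Nc1nnc(Cc2cccc3ccccc23)s1` were tested in an ADME assay on HEK-293T cells (Homo sapiens) for inhibition, read by CCK-8 assay, with a stated time of 48 h, tested at 20 uM; on this read-out higher numbers stand for more inhibition of growth at the one concentration tested and lower numbers for less inhibition of growth. Compound 1 gave 16% and compound 2 gave 15%, so the change fluoro in place of chloro on an aromatic carbon made a step of a number 1 percentage points lower from compound 1 to compound 2 (within the scatter). Compound 3 `Cc1ccc(Cc2nnc(NC(=O)/C(C#N)=C/c3ccccc3OS(=O)(=O)c3ccc(Cl)cc3)s2)cc1` differs from compound 1 by 4-methylphenyl in place of naphthalen-1-yl on a saturated chain carbon bound to an aromatic carbon; in this assay compound 3 gave 8%, a step of a number 8 percentage points lower from compound 1 to compound 3 (within the scatter). For the measured compounds named here, compound 4 `Cc1ccc(Cc2nnc(NC(=O)/C(C#N)=C/c3ccccc3OS(=O)(=O)c3ccc(F)cc3)s2)cc1` carries the same change as the one from compound 1 to compound 2, here (fluoro in place of chloro on an aromatic carbon), made on the core of compound 3. Because the earlier step of a number 1 percentage points lower from compound 1 to compound 2 (within the scatter) stayed within the scatter, the step from compound 3 to compound 4 is expected to be about a number 1 percentage points lower from compound 3 to compound 4 (within the scatter). Compound 4 is therefore estimated at 7%, with a likely range from 0% to 17%.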

Compound 4, percent growth inhibition at one concentration: 11%
Compound 4: middle estimate off by 4 percentage points, on the low side, and the stated range covers the measured number.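

In this assay, fluoro in place of chloro on the core of compound 3 gave a number 3 percentage points higher from compound 3 to compound 4 (within the scatter), which agrees with the same change on the core of compound 1: the same change on two cores in this assay, a number 1 percentage points lower (within the scatter) from compound 1 to compound 2 and a number 3 percentage points higher (within the scatter) from compound 3 to compound 4, 4 percentage points apart, within the scatter of two such steps. The change from naphthalen-1-yl to 4-methylphenyl, seen again as a number 4 percentage points lower from compound 2 to compound 4 (within the scatter), also agrees across cores: the same change on two cores in this assay, a number 8 percentage points lower (within the scatter) from compound 1 to compound 3 and a number 4 percentage points lower (within the scatter) from compound 2 to compound 4, 4 percentage points apart, within the scatter of two such steps. For the compounds shown here, every one of these steps lies within the scatter, so the agreement shows only that neither change stood out on these cores, not that either has a real effect or would carry to other cores.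

The compounds shown leave open what bromo or methoxy in place of chloro would do. They also leave open the effect of an amine or a carboxylic acid in place of the 4-methylphenyl group.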